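Aryl swap at the imine of the shared core

The source may hold more compounds than are shown below. What is called first, only, known or untested is meant among the compounds shown, and "the series" means these compounds.

Three members of this series have been run in an ADME assay on HeLa cells (Homo sapiens) for cytotoxicity, read by MTT assay, with a stated time of 72 h; on this read-out lower numbers stand for higher toxicity in this test and higher numbers for lower toxicity in this test. Compound 1, `Fc1ccc(/C=N/c2sc3c(c2-c2nc4ccccc4s2)CCCC3)cc1`, gives 277 ug/mL. Compound 2, `Clc1ccc(/C=N/c2sc3c(c2-c2nc4ccccc4s2)CCCC3)cc1`, gives 431 ug/mL. Compound 3, `Clc1ccccc1/C=N/c1sc2c(c1-c1nc3ccccc3s1)CCCC2`, gives 407 ug/mL. Together with compound 1 and compound 2, compound 3 sits inside one cluster: the step of a 1.5-fold higher number from compound 1 to compound 3 (0.17 log units; within the scatter) and the step of a 1.1-fold lower number from compound 2 to compound 3 (0.02 log units; within the scatter) both stay within the scatter, as does a 1.6-fold higher number from compound 1 to compound 2 (0.19 log units; within the scatter). Nothing among the three measured numbers separates one aryl group from another.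

Compound 4 is `O=[N+]([O-])c1ccc(/C=N/c2sc3c(c2-c2nc4ccccc4s2)CCCC3)cc1`. Among the compounds with values here, its single difference from compound 3 is 4-nitrophenyl in place of 2-chlorophenyl on a carbon with a double bond to nitrogen. Within the data shown here, none of the measured steps covers this exchange: the available comparisons only move a chlorine around the ring or replace fluorine by chlorine, and each of them stays within the scatter. Among the measured compounds shown here, the change to 4-nitrophenyl is larger in count than any of those, so the outcome is less tied down, but the only evidence in hand points to no movement beyond the scatter.

Compound 4 is therefore expected to give about 380 ug/mL in this assay, estimated between 190 ug/mL and 760 ug/mL. The step this estimate implies, a 1.1-fold lower number from compound 3 to compound 4 (0.03 log units; within the scatter), is expected to stay within the scatter.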

Compound 4, half-maximal cytotoxic concentration: 357 ug/mL
The estimate for compound 4 lay 1.1-fold (0.03 log units) above the measured number, and the stated range covers the measured number.
By their numbers in this assay, from the lowest: compounds 1, 4, 3 and 2 (each within the scatter of the next).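

In this assay, 4-nitrophenyl in place of 2-chlorophenyl on a carbon with a double bond to nitrogen gives a 1.1-fold lower number from compound 3 to compound 4 (0.06 log units; within the scatter) and so stays in the cluster, even though this exchange brings in the hydrogen-bond acceptors and the double bond outside aromatic rings counted for 4-nitrophenyl, neither of which 2-chlorophenyl has. Nitro in place of chloro on an aromatic carbon gives a 1.2-fold lower number from compound 2 to compound 4 (0.08 log units; within the scatter) and nitro in place of fluoro gives a 1.3-fold higher number from compound 1 to compound 4 (0.11 log units; within the scatter) as well, so the series now shows a change larger than a halogen swap or a shift of chlorine around the ring without any step beyond the scatter. No measurement is available that would explain why these numbers stay together.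

An aryl group carrying an amine or a carboxylic acid, or a longer chain in place of the aryl ring, remains an open case at this place, and no group shown yet separates from the cluster. On these data alone, all four compounds share one core and one read-out, so whether the same picture holds on a changed core or in another test also stays open.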